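The compounds below may be only part of what the source reports. "The series", "measured", "known", "first", "only" and "open" are said of these compounds alone.

Measured so far:
compound 1 `Cc1nnc(CNC(=O)CN)n1-c1ccc(Cl)cc1C(=O)c1ccccc1` gives 0.94 mg/kg
compound 2 `Cc1nnc(CNC(=O)CN)n1-c1ccc(Cl)cc1C(=O)c1ccccc1Cl` gives 0.62 mg/kg

In a functional assay on the whole organism with Mus musculus as the target (a lower number here means that less compound is needed, a higher number that more compound is needed for the effect), compound 2 at 0.62 mg/kg sits within the scatter of compound 1 at 0.94 mg/kg and is not separated from it. Compound 3 `NCC(=O)NCc1nnc(C2CC2)n1-c1ccc(Cl)cc1C(=O)c1ccccc1Cl` differs from compound 2 by cyclopropyl in place of methyl on an aromatic carbon and nothing else. Among the compounds with values here, the one measured step of a 1.5-fold lower number from compound 1 to compound 2 (0.18 log units; within the scatter) is chloro in place of hydrogen, not a change at this place, and stays within the scatter. Within the data shown here, no measured step covers the methyl, and no step beyond the scatter is expected in this assay for this change. The expected change is a 1.3-fold higher number from compound 2 to compound 3 (0.11 log units; within the scatter) as estimated here. Compound 3 is estimated at 0.8 mg/kg with an expected range from 0.3 mg/kg to 2.2 mg/kg in repeated measurements.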

Compound 3, dose for half-maximal effect: 0.49 mg/kg
Compound 3: middle estimate off by 1.6-fold (0.21 log units), on the high side; the range from low to high includes it.
By their numbers in this assay, from the lowest: compounds 3, 2 and 1 (each within the scatter of the next).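

In this assay, within the data shown here, the first measured change on the aromatic carbon between two ring nitrogen atoms is a 1.3-fold lower number from compound 2 to compound 3 (0.10 log units; within the scatter) and so stays within the scatter. Methyl is therefore not required here, and cyclopropyl is accepted at this place on the core of compound 2. Nothing available explains this result.

As far as these compounds go, an amine, a carboxylic acid or a longer chain such as n-butyl at this carbon remains open. Also open, from the compounds shown here alone, is whether cyclopropyl behaves the same way on the core of compound 1, which lacks the added chloro.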